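A New Aryl Group on the Ring Nitrogen

The source may report more compounds than this note shows. Statements on the series, on what has been measured and on what is new or still open speak of the compounds shown alone.

Of the compounds shown here, three with a shared core have been measured in a functional assay on HT-29 cells (Homo sapiens) for inhibition, read by MTT assay, with a stated time of 72 h; on this read-out higher numbers stand for weaker inhibition and lower numbers for stronger inhibition. Compound 1 `COc1cc2c(Oc3ccc(NC(=O)c4nn(-c5ccccc5C(F)(F)F)c(=O)cc4C)cc3F)ccnc2cc1OCCCN1CCCC1` gives 140 nM in this assay. Compound 2 `COc1cc2c(Oc3ccc(NC(=O)c4nn(-c5ccccc5C(F)(F)F)c(=O)cc4C)cc3F)ccnc2cc1OCCCN1CCC(C)CC1` gives 180 nM, and compound 3 `COc1cc2c(Oc3ccc(NC(=O)c4nn(-c5ccccc5C(F)(F)F)c(=O)cc4C)cc3F)ccnc2cc1OCCCN1CCN(C)CC1` gives 170 nM. The steps among them are all small: a 1.3-fold higher number from compound 1 to compound 2 (0.11 log units; within the scatter), a 1.2-fold higher number from compound 1 to compound 3 (0.08 log units; within the scatter) and a 1.1-fold lower number from compound 2 to compound 3 (0.02 log units; within the scatter). Compound 2 has the highest of the three numbers, but its nearest neighbour compound 3 and its furthest neighbour compound 1 both lie within the scatter of it, so no order can be read among them.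

Compound 4 `COc1cc2c(Oc3ccc(NC(=O)c4nn(-c5cccc(F)c5)c(=O)cc4C)cc3F)ccnc2cc1OCCCN1CCC(C)CC1` differs from compound 2 in a single place: 3-fluorophenyl in place of 2-(trifluoromethyl)phenyl on an aromatic nitrogen. Among the measured compounds shown here, every measured step so far concerns the amine at the end of the three-carbon chain, and none touches the aryl group on the ring nitrogen, so no measured step bears directly on this change. With nothing to point one way or the other, the step of no change at the digits printed from compound 2 to compound 4 (within the scatter) is expected to stay within the scatter, and the range around it is taken broad. Compound 4 is therefore estimated at 180 nM in this assay, with a range from 60 nM to 540 nM.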

Compound 4, half-maximal inhibitory concentration: 300 nM
Compound 4: the middle estimate sits 1.7-fold (0.22 log units) below what was measured, and the stated range covers the measured number.
By their numbers in this assay, from the lowest: compounds 1, 3, 2 and 4 (each within the scatter of the next, the first and the last beyond it).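

Among the compounds shown here, this is the only measured step that touches the aryl group on the ring nitrogen, and in this assay it reads as a 1.7-fold higher number from compound 2 to compound 4 (0.22 log units; within the scatter), so the earlier steps at the amine are no longer the only ones that stay within the scatter. Exchanging 2-(trifluoromethyl)phenyl, with 10 heavy atoms, for 3-fluorophenyl, with 7, therefore leaves the read-out within the scatter in this one pair, which carries the 4-methylpiperidin-1-yl amine at the end of the chain. No evidence is available that would account for this result or attach a property to either aryl group.

A single pair cannot show whether the same exchange stays within the scatter when the amine is the pyrrolidin-1-yl group of compound 1 or the 4-methylpiperazin-1-yl group of compound 3. It also leaves open how the read-out would respond to an unsubstituted phenyl, a methoxyphenyl or a pyridinyl group on the ring nitrogen, or to a small alkyl group such as methyl there in place of an aryl ring.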